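This account rests on a few compounds, and the source may have more. Where it says the series, first, only, none or still open, it means among the compounds named here.

Compound 3 `C#CCN(CCCCOc1ccc2ccc(=O)oc2c1)Cc1ccc(C)cc1` gives 94500 nM in an ADME assay on isolated protein for inhibition of Amine oxidase [flavin-containing] A (Homo sapiens), read by fluorescence and Amplex Red, with stated times of 15 min and 20 min (a lower number here means a stronger inhibitor, a higher number a weaker inhibitor), the highest of the three numbers, though still within the scatter of compound 1 `C#CCN(CCCCOc1ccc2ccc(=O)oc2c1)Cc1ccc(OC)cc1` at 54500 nM and of compound 2 `C#CCN(CCCCOc1ccc2ccc(=O)oc2c1)Cc1cccc(F)c1` at 69200 nM. Compound 4 `C#CCN(CCCCOc1ccc2ccc(=O)oc2c1)Cc1ccc(F)c(F)c1` has not been measured; it differs from compound 3 by 3,4-difluorophenyl in place of 4-methylphenyl on a saturated chain carbon bound to an amine nitrogen. For the measured compounds named here, the steps that bear on such a swap of one aryl group for another are a 1.4-fold higher number from compound 2 to compound 3 (0.14 log units; within the scatter) and a 1.3-fold higher number from compound 1 to compound 2 (0.10 log units; within the scatter), both within the scatter, so changing the group on this carbon has so far moved nothing beyond the usual noise. Compound 4 is therefore expected to show a step of a 1.3-fold lower number from compound 3 to compound 4 (0.10 log units; within the scatter), not beyond the scatter. The estimate for compound 4 is 75000 nM, between 35000 nM and 160000 nM.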

Compound 4, half-maximal inhibitory concentration: 93200 nM
Beside the measured number, compound 4's estimate is 1.2-fold (0.09 log units) below it; the range from low to high includes it.
By their numbers in this assay, from the lowest: compounds 1, 2, 4 and 3 (each within the scatter of the next).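

In this assay, fluoro in place of hydrogen on an aromatic carbon gives a 1.3-fold higher number from compound 2 to compound 4 (0.13 log units; within the scatter), so this added fluorine leaves the number within the scatter. The two swaps of a whole aryl group, a 1.0-fold lower number from compound 3 to compound 4 (0.01 log units; within the scatter) and a 1.7-fold higher number from compound 1 to compound 4 (0.23 log units; within the scatter), also stay within the scatter, which means that a difluorinated ring now joins the methoxy, methyl and single-fluoro rings with no separation among them. No measurement shown here accounts for this flat result. On these data alone, what remains open is whether a phenyl ring carrying a carboxylic acid or an amine on this carbon would move the number beyond the scatter.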